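Series notes: from compound 2 toward compound 4

The compounds below may be only part of what the source reports. "The series", "measured", "known", "first", "only" and "open" are said of these compounds alone.

In a functional assay on MOLT-4 cells (Homo sapiens) for antiproliferative activity, with a stated time of 48 h (on this read-out lower numbers stand for stronger inhibition and higher numbers for weaker inhibition), compound 1 `C=C(Br)C(=O)Nc1ccc(/C=C/C(=O)c2ccccc2)cc1` gives 3100 nM. Compound 2 `C=C(Br)C(=O)Nc1ccc(/C=C/C(=O)c2ccc(F)cc2)cc1` gives 660 nM, and compound 3 `C=C(Br)C(=O)Nc1ccc(/C=C/C(=O)c2ccc(OC)cc2)cc1` gives 1300 nM. Within the data shown here, compound 2 holds the lowest of the three numbers, but only the step of a 4.7-fold lower number from compound 1 to compound 2 (0.67 log units; beyond the scatter) lies beyond the scatter, while a 2.0-fold higher number from compound 2 to compound 3 (0.29 log units; within the scatter) does not.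

Compound 4 `C=C(Br)C(=O)Nc1ccc(/C=C/C(=O)c2ccc(OCC)cc2)cc1` differs from compound 2 in that (ethoxy in place of fluoro on an aromatic carbon). The step bearing most directly on this is a 2.0-fold higher number from compound 2 to compound 3 (0.29 log units; within the scatter), with the related 2.4-fold lower number from compound 1 to compound 3 (0.38 log units; beyond the scatter) showing where methoxy lands relative to hydrogen. A step of similar size toward a higher number, possibly still within the scatter, is therefore expected, namely a 2.0-fold higher number from compound 2 to compound 4 (0.29 log units; within the scatter). For compound 4 in this assay the estimate is 1300 nM, with a range of 500 nM to 3500 nM.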

Compound 4, half-maximal inhibitory concentration: 610 nM
For compound 4 the middle estimate is 2.1-fold (0.33 log units) above the measured one; measured number inside the range.
By their numbers in this assay, from the lowest: compounds 4, 2 and 3 (each within the scatter of the next, the first and the last beyond it); then compound 1.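

With a 1.1-fold lower number from compound 2 to compound 4 (0.03 log units; within the scatter) in this assay ethoxy stands level with fluoro on this aromatic carbon, para to a large group. The methyl added to methoxy does count, with a 2.1-fold lower number from compound 3 to compound 4 (0.33 log units; beyond the scatter) as its step, and with a 5.1-fold lower number from compound 1 to compound 4 (0.71 log units; beyond the scatter) on the same carbon ethoxy also keeps a clear gain over hydrogen. Nothing measured for these compounds accounts for the methyl step.

As far as these compounds go, whether a longer chain such as propoxy or butoxy holds this level remains open. So does how an amine or a carboxylic acid on this carbon would compare.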